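Amino to Aminomethyl: One Step in Trypsin Inhibition

The source may report more compounds than this note shows. Statements on the series, on what has been measured and on what is new or still open speak of the compounds shown alone.

Of the compounds shown here, three have been measured in an assay on isolated protein for inhibition of Trypsin (Homo sapiens), read by fluorescence, with a stated time of 15 min; a lower number here means a stronger inhibitor, a higher number a weaker inhibitor. Compound 1 `N=C(N)Nc1ccc(OC(=O)c2ccc(NC(=N)N)cc2)cc1` gives 1.35 nM, compound 2 `N=C(N)NCCCOC(=O)c1ccc(NC(=N)N)cc1` gives 9840 nM, and compound 3 `N=C(N)Nc1ccc(C(=O)Oc2ccc(N)cc2)cc1` gives 28 nM. Compound 3 thus holds the second highest number of the three: its nearest neighbour is compound 1, which lies well below it, and its furthest is compound 2, which lies far above it. Among the measured compounds shown here, the single step that has been measured in one place is a 21-fold higher number from compound 1 to compound 3 (1.32 log units; beyond the scatter), a hydrogen atom in place of a guanidine on the aromatic nitrogen.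

Compound 4 `N=C(N)Nc1ccc(C(=O)Oc2ccc(CN)cc2)cc1` differs from compound 3 by aminomethyl in place of amino on an aromatic carbon. For the measured compounds named here, no measured step concerns this exact change. The step from compound 1 to compound 3 alters the same end of the molecule and is large, so that end is clearly sensitive to what is attached there. Compound 2, which carries its second guanidine on a chain, gives 9840 nM, and this points nowhere definite for an aminomethyl. Compound 4 is therefore expected to give 15 nM, with a range from 3 nM to 80 nM. The expected step is a 1.9-fold lower number from compound 3 to compound 4 (0.27 log units; within the scatter), toward a lower number, but likely not beyond the scatter.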

Compound 4, half-maximal inhibitory concentration: 1.56 nM
Compound 4: middle estimate off by 9.6-fold (0.98 log units), on the high side; measured number outside the range, below it.
By their numbers in this assay, from the lowest: compounds 1 and 4 (each within the scatter of the next); then compound 3; then compound 2.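

In this assay, aminomethyl in place of amino on this aromatic carbon is itself a large change, with an 18-fold lower number from compound 3 to compound 4 (1.25 log units; beyond the scatter) for what amounts to a single added carbon. The earlier compounds shown here showed only that this end of the molecule responds when a guanidine is removed, whereas here a far smaller group recovers what that removal lost: the guanidine is not required for a low number, as a 1.2-fold higher number from compound 1 to compound 4 (0.06 log units; within the scatter) is within the scatter. Nothing measured explains why this small change counts for so much.

The compounds shown leave open whether aminoethyl, with its longer chain, would hold the number at this place. They also do not tell how a dimethylamino group or a carboxylic acid there would compare with aminomethyl.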